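A Halogenated Phenyl Replaces an Ethoxyphenyl on Nitrogen

This account rests on a few compounds, and the source may have more. Where it says the series, first, only, none or still open, it means among the compounds named here.

Measured so far in a functional assay on A549 cells (Homo sapiens) for antiproliferative activity, read by MTT assay, with a stated time of 48 h; on this read-out higher numbers stand for weaker inhibition and lower numbers for stronger inhibition:
- compound 1 `COc1ccc(-n2nncc2CN2C(=O)C3(C(C#N)=C(N)Oc4c3c3nc5ccccc5nc3c3ccccc43)c3ccccc32)cc1` gives > 50000 nM, a limit of the assay rather than a number
- compound 2 `CCOc1ccc(-n2nncc2CN2C(=O)C3(C(C#N)=C(N)Oc4c3c3nc5ccccc5nc3c3ccccc43)c3ccccc32)cc1` gives 25200 nM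
- compound 3 `CCOc1ccc(-n2nncc2CN2C(=O)C3(C(C#N)=C(N)Oc4c(N)cc5nc6ccccc6nc5c43)c3ccccc32)cc1` gives > 50000 nM, again a limit and not a number

Compound 3 thus sits at the limit of > 50000 nM in this assay, at which 2 of the 3 values shown sit. Going by the values given here, the only measured step, an at least 1.9-fold lower number from compound 1 to compound 2 (0.29 log units; that floor lies within the scatter), alters the chain on the oxygen and does not touch the place changed here. Compound 4 `N#CC1=C(N)Oc2c(N)cc3nc4ccccc4nc3c2C12C(=O)N(Cc1cnnn1-c1ccc(F)c(Cl)c1)c1ccccc12` differs from compound 3 by 3-chloro-4-fluorophenyl in place of 4-ethoxyphenyl on an aromatic nitrogen. Among the compounds with values here, no measured step bears on this change, so no direction can be drawn from the data. With compound 3 at a limit, compound 4 is expected to stay near that edge, an at least 1.2-fold lower number from compound 3 to compound 4 (0.09 log units; that floor lies within the scatter). Compound 4 is estimated at 40000 nM, between 12000 nM and 150000 nM.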

Compound 4, half-maximal inhibitory concentration: 43400 nM
For compound 4 the middle estimate is 1.1-fold (0.04 log units) below the measured one; the range from low to high includes it.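

In this assay, 3-chloro-4-fluorophenyl in place of 4-ethoxyphenyl on the aromatic nitrogen gives an at least 1.1-fold lower number from compound 3 to compound 4 (0.06 log units; that floor lies within the scatter). So this swap of one substituted phenyl for another brings no gain that can be told from the scatter, although compound 4 has a measured number. Compound 3 remains a limit of the assay and not a number: the limit of > 50000 nM in this assay, at which 2 of the 4 values shown sit.

As far as these compounds go, it remains open whether an amine or a carboxylic acid on this phenyl ring would shift the number clearly. From the compounds shown here alone, it is also open whether 3-chloro-4-fluorophenyl would do so on the core of compound 2.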